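A few compounds are considered here, and "the series" means these few. Any claim that something is new, unique, unknown or untested is made for them only; others in the source may bear on it.

Measured compounds:
- compound 1, `COc1ccc(-c2cc(C(=O)Nc3nc4ccc(Cl)cc4s3)nc3cc(-c4ccccc4)nn23)cc1OC`, gives 7760 nM in a functional assay on ACHN cells (Homo sapiens) for cytotoxicity, read by MTT assay, with a stated time of 48 h; a lower number here means a stronger inhibitor, a higher number a weaker inhibitor
- compound 2, `COc1cc(-c2cc(C(=O)Nc3nc4ccc(Cl)cc4s3)nc3cc(-c4ccccc4)nn23)cc(OC)c1OC`, gives 41700 nM in this assay

Going by the values given here, compound 2 stands at the highest of the two numbers, with compound 1 the nearest measured neighbour; the one measured step, a 5.4-fold higher number from compound 1 to compound 2 (0.73 log units; beyond the scatter), separates them. Compound 3, `COc1cc(-c2cc(C(=O)Nc3nc4ccc(F)cc4s3)nc3cc(-c4ccccc4)nn23)cc(OC)c1OC`, has not yet been measured. It differs from compound 2 only in this: fluoro in place of chloro on an aromatic carbon. Among the compounds with values here, no measured step concerns a halogen exchange on this ring; the only known step concerns a methoxy group on a different ring and so gives no guide to the size or direction of this change. In the absence of such a guide, the expectation is for no step beyond the scatter. Compound 3 is therefore expected to give 50000 nM, with a likely range from 15000 nM to 150000 nM. This estimate amounts to an expected 1.2-fold higher number from compound 2 to compound 3 (0.08 log units; within the scatter).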

Compound 3, half-maximal inhibitory concentration: 32400 nM
Estimate against measurement, compound 3: 1.5-fold (0.19 log units) above, within the range that was stated.
By their numbers in this assay, from the lowest: compound 1; then compounds 3 and 2 (each within the scatter of the next).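

Fluoro in place of chloro, changing the 6-chloro-1,3-benzothiazol-2-yl group to the 6-fluoro-1,3-benzothiazol-2-yl group, gives a 1.3-fold lower number from compound 2 to compound 3 (0.11 log units; within the scatter) in this assay. Going by these compounds alone, this is the first measured change on this ring, and in this assay the exchange of one halogen for the other cannot be told apart from no change at all. The earlier step, on a methoxy group elsewhere in the molecule, lay beyond the scatter, whereas this one does not, and no accompanying measurement offers an explanation for the result.

The compounds shown leave open whether a group of another kind at this position, such as an amine or a carboxylic acid, would move the number beyond the scatter. They also leave open whether the same halogen exchange would read the same way on compound 1.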